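Swapping Methyl for 2-Chlorophenyl on the Fused Core

The source may hold more compounds than are shown below. What is called first, only, known or untested is meant among the compounds shown, and "the series" means these compounds.

Compound 1 `O=S(=O)(Nc1ccc(F)c(C#Cc2ccc3[nH]ncc3c2)c1F)c1cccnc1`: > 10000 nM
Compound 2 `Cc1n[nH]c2ncc(C#Cc3c(F)ccc(NS(=O)(=O)c4cccnc4)c3F)cc12`: 148 nM

In a functional assay on COLO 205 cells (Homo sapiens) for antiproliferative activity, read by MTT assay, with a stated time of 68 h (on this read-out higher numbers stand for weaker inhibition and lower numbers for stronger inhibition), compound 1 gives only a limit, > 10000 nM; this is the limit of > 10000 nM in this assay, at which 1 of the 2 values shown sits. Among the measured compounds shown here, compound 2 gives 148 nM in this assay, the only actual number among the two values. For the measured compounds named here, the sole measured step, an at least 67-fold lower number from compound 1 to compound 2 (1.82 log units; beyond the scatter), alters the fused core itself and leaves the methyl untouched.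

Compound 3 `O=S(=O)(Nc1ccc(F)c(C#Cc2cnc3[nH]nc(-c4ccccc4Cl)c3c2)c1F)c1cccnc1` differs from compound 2 by 2-chlorophenyl in place of methyl on an aromatic carbon. Going by the values given here, no measured step bears on this change, so the data give no direction for it. The expected value for compound 3 is 120 nM, within 25 nM to 700 nM. For compound 3 the estimate amounts to a 1.2-fold lower number from compound 2 to compound 3 (0.09 log units; within the scatter), expected to stay within the scatter.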

Compound 3, half-maximal inhibitory concentration: 3600 nM
The estimate for compound 3 lay 30-fold (1.48 log units) below the measured number, outside the stated range (above it).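

In this assay, among the compounds shown here, the swap of methyl for 2-chlorophenyl on this aromatic carbon of the five-membered aromatic ring brings a 24-fold higher number from compound 2 to compound 3 (1.39 log units; beyond the scatter) and so shows, for the first time, that the number responds strongly to what sits at this place. Of the two groups seen here, methyl goes with the lower number. Nothing measured here accounts for the size of this step.

The compounds shown cannot separate the part played by the chlorine from that of the phenyl ring. As far as these compounds go, how an ethyl, a plain phenyl or an amine at this carbon would compare also remains open.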